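Series notes: aryl change on the carbon double-bonded to nitrogen

The source may report more compounds than this note shows. Statements on the series, on what has been measured and on what is new or still open speak of the compounds shown alone.

Measured so far, in a functional assay on NCI-H460 cells (Homo sapiens) for cytotoxicity, read by MTT assay, with a stated time of 72 h; on this read-out higher numbers stand for weaker inhibition and lower numbers for stronger inhibition:
- compound 1, `CN(C)CCn1cnnc1-c1cc(Oc2ccc(NC(=O)N/N=C/c3c[nH]c4ccccc34)cc2F)ccn1`: 1630 nM
- compound 2, `CN(C)CCn1cnnc1-c1cc(Oc2ccc(NC(=O)N/N=C/c3ccccc3O[N+](=O)[O-])cc2F)ccn1`: 1270 nM
- compound 3, `Cn1ncnc1-c1cc(Oc2ccc(NC(=O)N/N=C/c3ccccc3)cc2F)ccn1`: 52200 nM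

Compound 2 holds the lowest of the three numbers; compound 1 lies nearest, with a 1.3-fold lower number from compound 1 to compound 2 (0.11 log units; within the scatter), and compound 3, which differs from compound 2 in more than one place, gives a far higher value.

Compound 4, `CN(C)CCn1cnnc1-c1cc(Oc2ccc(NC(=O)N/N=C/c3cccc(Cl)c3Cl)cc2F)ccn1`, carries 2,3-dichlorophenyl in place of 2-(nitrooxy)phenyl on a carbon with a double bond to nitrogen. Within the data shown here, the only measured step at this position is a 1.3-fold lower number from compound 1 to compound 2 (0.11 log units; within the scatter), an aryl exchange that stayed within the scatter. No step beyond the scatter is therefore expected in this assay for compound 4: the estimated change is a 1.1-fold higher number from compound 2 to compound 4 (0.04 log units; within the scatter). Compound 4 is expected to give about 1400 nM, within 500 nM to 4000 nM.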

Compound 4, half-maximal inhibitory concentration: 72 nM
The estimate for compound 4 lay 19-fold (1.29 log units) above the measured number; measured number outside the range, below it.
By their numbers in this assay, from the lowest: compound 4; then compounds 2 and 1 (each within the scatter of the next); then compound 3.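

In this assay, the aryl group on the carbon with a double bond to nitrogen can shift the number well beyond the scatter, which the exchange between compound 1 and compound 2 gave no sign of. With 2,3-dichlorophenyl entering, the drop is an 18-fold lower number from compound 2 to compound 4 (1.25 log units; beyond the scatter) against 2-(nitrooxy)phenyl and a 23-fold lower number from compound 1 to compound 4 (1.35 log units; beyond the scatter) against 1H-indol-3-yl. No measurement at hand explains this drop.

Open, from the compounds shown here alone, is whether both chlorine atoms are needed, and whether a monochlorophenyl, a methoxyphenyl or an aminophenyl group at this position would keep the low number.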